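This account rests on a few compounds, and the source may have more. Where it says the series, first, only, none or still open, it means among the compounds named here.

Four close relatives of one dihydropyridine diester were compared in a functional assay on cardiac atrium (Cavia porcellus); on this read-out higher numbers stand for an effect only at larger amounts of compound and lower numbers for an effect already at smaller amounts. Compound 1 `COC(=O)C1=C(C)NC(C)=C(C(=O)OC)C1c1c(-c2cccnc2)nc2sc(C)cn12` gives 12500 nM. Compound 2 `COC(=O)C1=C(C)NC(C)=C(C(=O)OC)C1c1c(-c2ccsc2)nc2sc(C)cn12` differs from it by one change, (thiophen-3-yl in place of pyridin-3-yl on an aromatic carbon), and gives 2300 nM; this change brought a 5.4-fold lower number from compound 1 to compound 2 (0.74 log units; beyond the scatter). Compound 3 `COC(=O)C1=C(C)NC(C)=C(C(=O)OC)C1c1c(-c2cccnc2)nc2sccn12` differs from compound 1 in the core, (hydrogen in place of methyl on an aromatic carbon). Compound 3 gives 28400 nM, the highest number of the three; the step was a 2.3-fold higher number from compound 1 to compound 3 (0.36 log units; beyond the scatter).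

Compound 4 `COC(=O)C1=C(C)NC(C)=C(C(=O)OC)C1c1c(-c2ccsc2)nc2sccn12` has not been measured. It carries the core of compound 3 and the change (thiophen-3-yl in place of pyridin-3-yl on an aromatic carbon). Its place line reads the same, word for word, as that for the step from compound 1 to compound 2, so the change is the same one, made on the core that lacks the methyl.

Because a 5.4-fold lower number from compound 1 to compound 2 (0.74 log units; beyond the scatter) was seen on the core of compound 1, the same kind of step is expected on the core of compound 3, so the expected change for compound 4 is a 5.4-fold lower number from compound 3 to compound 4 (0.73 log units; beyond the scatter). The expected value for compound 4 is 5300 nM, with a likely range from 2500 nM to 11000 nM.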

Compound 4, half-maximal effective concentration: 1060 nM
Estimate against measurement, compound 4: 5.0-fold (0.70 log units) above, and the stated range ends above it.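

In this assay, thiophen-3-yl in place of pyridin-3-yl gave a 27-fold lower number from compound 3 to compound 4 (1.43 log units; beyond the scatter), so this change lowered the number on both cores, but its size did not carry over from one core to the other: the same change on two cores in this assay, a 5.4-fold lower number (0.74 log units; beyond the scatter) from compound 1 to compound 2 and a 27-fold lower number (1.43 log units; beyond the scatter) from compound 3 to compound 4, 4.9-fold (0.69 log units) apart, beyond the scatter of two such steps Hydrogen in place of methyl gave a 2.2-fold lower number from compound 2 to compound 4 (0.34 log units; beyond the scatter), whereas the same change raised the number in the pyridin-3-yl pair, so here even the direction depended on the group elsewhere in the molecule: the same change on two cores in this assay, a 2.3-fold higher number (0.36 log units; beyond the scatter) from compound 1 to compound 3 and a 2.2-fold lower number (0.34 log units; beyond the scatter) from compound 2 to compound 4, 4.9-fold (0.69 log units) apart, beyond the scatter of two such steps These four compounds show that the two changes do not act independently in this series, but they do not show why, and a single set of four cannot give a rule for other cores.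

From the compounds shown here alone, it remains open whether a phenyl or furan-3-yl group in place of pyridin-3-yl would follow the thiophen-3-yl result. Going by these compounds, it is also open whether an ethyl group in place of the methyl would shift the number in the same way on both sides of this comparison.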